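Swapping the para substituent on the aryl ring of compound 1

This account rests on a few compounds, and the source may have more. Where it says the series, first, only, none or still open, it means among the compounds named here.

Compound 1 has the structure `CCN(CC)c1ccc(N2C(=O)NC3(CSC4=C3C(=O)c3ncccc3C4=O)C2=O)cc1` and is tested in a functional assay on HeLa cells (Homo sapiens) for antiproliferative activity, read by MTT assay, with a stated time of 96 h (a lower number here means a stronger inhibitor, a higher number a weaker inhibitor), where compound 1 gives 50 nM. Among the measured compounds shown here, this is the lowest of the three numbers so far. Compound 3 has the structure `Cc1ccc(N2NC(=O)NC3(CSC4=C3C(=O)c3ncccc3C4=O)C2=O)cc1`, and in this assay compound 3 gives 210 nM. Compound 2 has the structure `O=C1NNC(=O)C2(CSC3=C2C(=O)c2ncccc2C3=O)N1`, and in this assay compound 2 gives 980 nM. For the measured compounds named here, the only single-point step among the measured compounds is a 4.7-fold lower number from compound 2 to compound 3 (0.67 log units; beyond the scatter), which shows how much an aryl group on a ring nitrogen matters.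

The new compound 4 has the structure `O=C1C2=C(C(=O)c3ncccc31)C1(CS2)NC(=O)N(c2ccc([N+](=O)[O-])cc2)C1=O`. Compared with compound 1, the change is nitro in place of diethylamino on an aromatic carbon. Going by the values given here, no measured step exchanges one substituent on that aryl ring for another, so nothing directly shows what the swap does; the aryl ring itself stays in place. The step of a 2.2-fold higher number from compound 1 to compound 4 (0.34 log units; beyond the scatter) is therefore expected to be small, possibly within the scatter, with a modest rise the likelier direction. In this assay compound 4 is estimated at 110 nM, with a range from 35 nM to 350 nM.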

Compound 4, half-maximal inhibitory concentration: 100 nM
Beside the measured number, compound 4's estimate is 1.1-fold (0.04 log units) above it; low and high end bracket the measured number.
By their numbers in this assay, from the lowest: compounds 1 and 4 (each within the scatter of the next); then compound 3; then compound 2.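

In this assay, among the compounds shown here, the exchange of diethylamino for nitro gives a 2.0-fold higher number from compound 1 to compound 4 (0.30 log units; within the scatter) and is the first direct reading of what a substituent does on this aromatic carbon, para to a large group. Although the two groups differ in their atoms, with five heavy atoms leaving and three entering, the numbers for the two compounds cannot be told apart, so for this pair the choice of group makes no measurable difference. Nothing measured here offers a reason for this outcome.

As far as these compounds go, it remains open whether the same holds for quite different groups in this place, such as a carboxylic acid, a primary amine or a longer alkyl chain. The compounds shown also leave open how a plain hydrogen in this place would compare with diethylamino and nitro.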